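A few compounds are considered here, and "the series" means these few. Any claim that something is new, unique, unknown or untested is made for them only; others in the source may bear on it.

Of the compounds shown here, three have been measured in a functional assay on BMDM cells (Mus musculus, strain C57BL/6) for inhibition, with a stated time of 2 days; a higher number here means a weaker inhibitor, a lower number a stronger inhibitor. Compound 1 `COc1ccc(-c2cn(CC(=O)Nc3cc(C)on3)nn2)cc1` and compound 2 `COc1ccc(-c2cn(CC(=O)Nc3nc(C)cs3)nn2)cc1` share one core and differ only in the ring on the amide-type nitrogen. In this assay compound 2 gives 3890 nM. For compound 1 this assay reports only a limit, > 30000 nM. The change between them, (5-methyl-1,2-oxazol-3-yl in place of 4-methyl-1,3-thiazol-2-yl on an amide-type nitrogen), produced an at least 7.7-fold higher number from compound 2 to compound 1 (0.88 log units; beyond the scatter), and the size of that step is known only as far as the limit of > 30000 nM in this assay, at which 1 of the 3 values shown sits.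

Compound 3 `Cc1csc(NC(=O)Cn2cc(-c3ccccc3Cl)nn2)n1` carries the same 4-methyl-1,3-thiazol-2-yl ring on another core; the difference between the core of compound 3 and the core of compound 2 is not broken down here. In this assay compound 3 gives 1240 nM, the lowest of the two numbers measured.

Compound 4 `Cc1cc(NC(=O)Cn2cc(-c3ccccc3Cl)nn2)no1` has not yet been measured. It differs from compound 3 by 5-methyl-1,2-oxazol-3-yl in place of 4-methyl-1,3-thiazol-2-yl on an amide-type nitrogen, the same change as that from compound 2 to compound 1, made at the same place. Among the compounds with values here, a step of comparable size is expected, a 12-fold higher number from compound 3 to compound 4 (1.08 log units; beyond the scatter), resting on the single earlier pair, an at least 7.7-fold higher number from compound 2 to compound 1 (0.88 log units; beyond the scatter). Because that earlier step ended at the limit of > 30000 nM in this assay, at which 1 of the 3 values shown sits, a similar outcome for compound 4 cannot be ruled out. Compound 4 is expected to give about 15000 nM, somewhere between 5000 nM and 40000 nM.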

Compound 4, half-maximal inhibitory concentration: > 30000 nM
Compound 4 gave a limit, no number; the forecaster's own chance of this, stated with the estimate: 35%; middle value at least 2.0-fold (0.30 log units) away from the limit.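

In this assay, putting 5-methyl-1,2-oxazol-3-yl in place of 4-methyl-1,3-thiazol-2-yl on the amide-type nitrogen again weakens inhibition on the second core, giving an at least 24-fold higher number from compound 3 to compound 4 (1.38 log units; beyond the scatter). The direction of the change therefore carries over from one core to the other, and on both cores the step lies beyond the usual scatter, although a comparison of the two sizes remains unsettled: the same change on two cores in this assay, an at least 7.7-fold higher number (0.88 log units; beyond the scatter) from compound 2 to compound 1 and an at least 24-fold higher number (1.38 log units; beyond the scatter) from compound 3 to compound 4; the limit leaves it open whether they differ. As far as these compounds go, the result for compound 4 is a limit and not a number, so the true size of this step stays unknown, and two cores alone cannot show that the same loss would appear on any further core: the limit of > 30000 nM in this assay, at which 2 of the 4 values shown sit.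

The swap replaces one whole ring with another, and the compounds shown do not reveal which part of the 4-methyl-1,3-thiazol-2-yl group matters for inhibition. From the compounds shown here alone, it also remains open whether an amine, a carboxylic acid or a longer chain in place of the methyl group on that ring would keep, improve or lose the inhibition seen with compound 3 and compound 2.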